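The source may report more compounds than this note shows. Statements on the series, on what has been measured and on what is new or still open speak of the compounds shown alone.

Working notes on the series. Compound 1, `C=CCN1C(=O)CNC1=[Se]`, is the simplest member; in a functional assay on SiHa cells (Homo sapiens) for cytotoxicity, read by MTT assay, with a stated time of 48 h (a higher number here means that more compound is tolerated, a lower number that less compound is tolerated), compound 1 gives 12700 nM. For the measured compounds named here, compound 2, `C=CCN1C(=O)/C(=C/c2ccccn2)N=C1[Se]C`, carries the pyridylmethylidene and methylselanyl groups on the shared core, and in this assay compound 2 gives 3660 nM, which stands as the lowest of the two numbers so far, with compound 1 as its nearest neighbour at a step beyond the scatter. Compound 3, `C=CCN1C(=O)/C(=C/c2ccccn2)N=C1SC`, has not yet been measured. From compound 2 to compound 3 the change is a group of 2 heavy atoms (1 carbon, 1 sulfur; no ring) in place of a group of 2 heavy atoms (1 carbon, 1 selenium; no ring), on a carbon with a double bond to nitrogen. Going by the values given here, no step of this kind between measured compounds exists, so the expected size rests on the change alone: a small step toward more tolerated compound, at the edge of the scatter, is expected for compound 3, a 1.6-fold higher number from compound 2 to compound 3 (0.21 log units; within the scatter). For compound 3 in this assay the estimate is 6000 nM, with a range from 2500 nM to 15000 nM.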

Compound 3, half-maximal cytotoxic concentration: 102000 nM
For compound 3 the middle estimate is 17-fold (1.23 log units) below the measured one; measured number above the stated range.
By their numbers in this assay, from the lowest: compound 2; then compound 1; then compound 3.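

Replacing the methylselanyl group with methylsulfanyl, on a carbon with a double bond to nitrogen, gives a 28-fold higher number from compound 2 to compound 3 (1.45 log units; beyond the scatter) in this assay and marks this position as highly sensitive to the exchange. For the compounds shown here, the number of heavy atoms in the group stays the same, so exchanging selenium for sulfur is enough for a large step in this pair, which the earlier compounds, lacking a one-place comparison, could not show. Nothing measured here accounts for the size of this step.

As far as these compounds go, this single pair sets no general rule for selenium against sulfur, and it remains open whether the step would persist with a phenyl group in place of the pyridine ring or a propyl chain in place of allyl. From the compounds shown here alone, how an amine or a longer alkylsulfanyl chain at this position would compare with either group also remains open.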